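A Naphthyl Analogue Awaits Its Cytotoxicity Value

This account rests on a few compounds, and the source may have more. Where it says the series, first, only, none or still open, it means among the compounds named here.

Compound 1 `O=C1N/C(=N/c2csc(-c3ccc(Cl)cc3)c2)S/C1=C\c1ccc(Br)cc1`: 3500 nM
Compound 2 `O=C1N/C(=N/c2csc(-c3ccc(Cl)cc3)c2)S/C1=C\c1ccc(O)cc1`: "not determined" (no result reported)

In a functional assay on MDA-MB-231 cells (Homo sapiens) for cytotoxicity, read by MTT assay, with a stated time of 72 h (on this read-out higher numbers stand for weaker inhibition and lower numbers for stronger inhibition), compound 1 gives 3500 nM. For compound 2 the result in this assay is recorded as "not determined" (no result reported), so compound 2 stands nowhere on the numbers and offers no anchor of its own. Compound 3 `O=C1N/C(=N/c2csc(-c3ccc(Cl)cc3)c2)S/C1=C\c1ccc2ccccc2c1` differs from compound 2 by naphthalen-2-yl in place of 4-hydroxyphenyl on a double-bonded chain carbon bound to a double-bonded ring carbon. Among the measured compounds shown here, no step between measured compounds is known, and compound 1 is the only compound with a number. The step in this assay is expected to be small, with no firm direction, and likely not beyond the scatter. Compound 3 is estimated at 3000 nM, within 800 nM to 12000 nM.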

Compound 3, half-maximal inhibitory concentration: 1800 nM
Compound 3: middle estimate off by 1.7-fold (0.22 log units), on the high side; the range from low to high includes it.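

In this assay, the step of a 1.9-fold lower number from compound 1 to compound 3 (0.29 log units; within the scatter) shows that, on a double-bonded chain carbon bound to a double-bonded ring carbon, naphthalen-2-yl and 4-bromophenyl give values within the scatter of each other. Compound 2 has no number, so the steps involving its 4-hydroxyphenyl group cannot be read. Nothing measured here gives a reason for this result.

The compounds shown leave open how an amine, a carboxylic acid or a longer chain at this place would read in this assay. They also leave open whether any group there would move the value beyond the scatter.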